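The source may report more compounds than this note shows. Statements on the series, on what has been measured and on what is new or still open speak of the compounds shown alone.

Compound 1 `N#Cc1ncn(Cc2ccccc2Cl)c1NC(=O)c1ccccc1`: 17100 nM
Compound 2 `COc1ccc(OC)c(/C=N/c2c(C#N)ncn2Cc2ccccc2Cl)c1`: 20000 nM
Compound 3 `N#Cc1ncn(Cc2ccccc2Cl)c1/N=C/c1ccc(O)cc1`: 38200 nM

All three were tested in a functional assay on HepG2 cells (Homo sapiens) for antiproliferative activity, read by MTT assay; a lower number here means a stronger inhibitor, a higher number a weaker inhibitor. Compound 3 carries the largest number of the three, yet its gap to compound 2 lies within the scatter, so those two cannot be told apart; only its gap to compound 1 lies beyond it. Compound 4 `N#Cc1ncn(Cc2ccccc2Cl)c1/N=C/c1ccc(Cl)cc1` is not yet measured. It differs from compound 3 in one place: chloro in place of hydroxy on an aromatic carbon. Among the compounds with values here, no pair of measured compounds shows what this change does here, so the expectation rests on the narrow band the three values span. The step from compound 3 to compound 4 is expected to be a 1.5-fold lower number from compound 3 to compound 4 (0.18 log units; within the scatter), small and possibly in either direction. Compound 4 is estimated at 25000 nM, with a range from 8000 nM to 70000 nM.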

Compound 4, half-maximal inhibitory concentration: 31000 nM
Estimate against measurement, compound 4: 1.2-fold (0.09 log units) below, and the stated range covers the measured number.
By their numbers in this assay, from the lowest: compounds 1, 2, 4 and 3 (each within the scatter of the next, the first and the last beyond it).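

In this assay, within the data shown here, replacing 4-hydroxyphenyl with 4-chlorophenyl gives a 1.2-fold lower number from compound 3 to compound 4 (0.09 log units; within the scatter), the first step in this set that isolates a single change. At this position, the hydroxy group, with its hydrogen-bond donor and acceptor, can therefore give way to chloro, which has neither, without a readable shift in this assay. Nothing measured here explains why the two groups read alike.

An amine or a carboxylic acid at the same position could still behave differently. On these data alone, it also remains open whether the same change would have a similar effect on the amide of compound 1.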